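The source may report more compounds than this note shows. Statements on the series, on what has been measured and on what is new or still open speak of the compounds shown alone.

Measured compounds in an assay on membranes from heart (Canis lupus familiaris) for displacement of a labelled ligand from sulfonylurea receptor 2, Kir6.2 (Homo sapiens); a higher number here means a weaker inhibitor, a lower number a stronger inhibitor:

- compound 1 `CC(/N=C(\NC#N)Nc1ccccc1)C(C)(C)C` gives 680 nM
- compound 2 `CCC(C)(C)/N=C(\NC#N)Nc1ccc(I)cc1` gives 74 nM
- compound 3 `CC(C)/N=C(\NC#N)Nc1ccc(C#N)cc1` gives 7300 nM

Among these three numbers compound 1 stands second highest: compound 2 sits well below it, beyond the scatter, and compound 3 sits well above it, also beyond the scatter. Going by the values given here, the pairs of these three compounds differ in more than one place, so no single step between them can be read off; the values only show that compound 1 lies between the two others.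

Compound 4 `CC(/N=C(\NC#N)Nc1cccc(C#N)c1)C(C)(C)C` is built from compound 1 by one change: cyano in place of hydrogen on an aromatic carbon. Among the compounds with values here, no measured pair describes this step on its own. What the values show is that compound 3, which also carries a cyano group on its aromatic ring, gives the highest number of the set, while compound 2, with an iodine on the ring, gives the lowest. On that basis a weakening step in this assay from compound 1 to compound 4 is expected, of moderate size, a 2.2-fold higher number from compound 1 to compound 4 (0.34 log units; beyond the scatter). Compound 4 is therefore estimated at 1500 nM, with a range from 400 nM to 6000 nM.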

Compound 4, inhibition constant: 350 nM
For compound 4 the middle estimate is 4.3-fold (0.63 log units) above the measured one, outside the stated range (below it).
By their numbers in this assay, from the lowest: compound 2; then compounds 4 and 1 (each within the scatter of the next); then compound 3.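

In this assay, cyano in place of hydrogen on an aromatic carbon, meta to a large group, gives a 1.9-fold lower number from compound 1 to compound 4 (0.29 log units; within the scatter) and so leaves compound 1 and compound 4 indistinguishable. Going by these compounds alone, this is the first single change that can be read in this set, and it shows that the core of compound 1 accepts a cyano group at this position with no step beyond the scatter. Nothing at hand offers an explanation for this result.

Going by these compounds, whether the same holds for other groups at this position, such as an amine, a carboxylic acid or an iodine atom, remains open, as does the reading of cyano at other places on the ring. The compounds shown also give no single step for the chain on the other side of the core, so the effect of a longer chain in place of the one in compound 1 is unknown.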